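The compounds below may be only part of what the source reports. "The series", "measured", "known", "first", "only" and "open" are said of these compounds alone.

In an ADME assay on HeLa cells (Homo sapiens) for cytotoxicity (on this read-out lower numbers stand for higher toxicity in this test and higher numbers for lower toxicity in this test), compound 1 `CCN(CC)CN1C(=O)/C(=N/NC(=S)Nc2ccc(OC)cc2)c2ccccc21` gives only the limit >= 4000 nM. Compound 2 `CCN(CC)CN1C(=O)/C(=N/NC(=S)Nc2ccccc2)c2ccccc21` likewise stands at a limit in this assay, namely >= 20000 nM. The step that the two limits leave unreadable from compound 1 to compound 2 cannot be read, since both values sit at limits the limit of >= 20000 nM in this assay, at which 1 of the 2 values shown sits (the limit of >= 4000 nM in this assay, at which 1 of the 2 values shown sits). Compound 3 `CCN(CC)CN1C(=O)/C(=N/NC(N)=S)c2ccccc21` differs from compound 2 by hydrogen in place of phenyl on an amide-type nitrogen. For the measured compounds named here, no measured step bears on this change, so no step beyond the scatter can be foreseen in either direction, and a further limit seems likely. Compound 3 is estimated at 20000 nM, within a range from 4000 nM to 60000 nM. The step this estimate means is expected to be a number no higher from compound 2 to compound 3 (the limit leaves the size open).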

Compound 3, minimum cytotoxic concentration: > 100000 nM
Compound 3 ended at the assay's limit; the forecaster's own chance of this, stated with the estimate: 80%; at least 5.0-fold (0.69 log units) between middle value and limit.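

In this assay compound 3 gives > 100000 nM as a limit. For the compounds shown here, compound 1, compound 2 and compound 3 all stand at limits, so no step among them can be read. The compounds shown leave open how large the change from anilino to amino is.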